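A Fluorine on the Urea Tail: Expected Potency

This account rests on a few compounds, and the source may have more. Where it says the series, first, only, none or still open, it means among the compounds named here.

Of the compounds shown here, three sharing one core have been measured for how strongly they slow the growth of a colon cancer cell line. Compound 1 `CN(C)CCNc1nc(-c2ccc(NC(=O)Nc3ccccc3)cc2)nc2ccsc12` has a plain phenyl urea and a short basic side chain; in a functional assay on HT-29 cells (Homo sapiens) for cytotoxicity, read by MTT assay, with a stated time of 72 h (a higher number here means a weaker inhibitor, a lower number a stronger inhibitor), compound 1 gives 620 nM. Compound 2 `CN(C)CCNc1nc(-c2ccc(NC(=O)Nc3ccc(F)cc3)cc2)nc2ccsc12` differs only by a fluorine on the outer phenyl ring, and in this assay compound 2 gives 350 nM. Compound 3 `CCN(CC)CCCNc1nc(-c2ccc(NC(=O)Nc3ccccc3)cc2)nc2ccsc12` keeps the plain phenyl urea but carries a longer side chain ending in a diethylamino group; in this assay compound 3 gives 730 nM.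

Compound 3 thus has the highest of the three numbers. Its nearest neighbour is compound 1, since the step of a 1.2-fold higher number from compound 1 to compound 3 (0.07 log units; within the scatter) is within the scatter, so these two cannot be told apart. The value of compound 2 lies furthest from that of compound 3, and that gap is beyond the scatter.

Compound 4 `CCN(CC)CCCNc1nc(-c2ccc(NC(=O)Nc3ccc(F)cc3)cc2)nc2ccsc12` is not yet measured. Its difference from compound 3 is fluoro in place of hydrogen on an aromatic carbon. The step that bears on this is a 1.8-fold lower number from compound 1 to compound 2 (0.25 log units; within the scatter), the same change made on the shorter side chain. The expected step is therefore a 1.7-fold lower number from compound 3 to compound 4 (0.24 log units; within the scatter), a small shift that stays within the scatter. The expected value for compound 4 in this assay is 420 nM, with a range from 200 nM to 900 nM.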

Compound 4, half-maximal inhibitory concentration: 340 nM
For compound 4 the middle estimate is 1.2-fold (0.09 log units) above the measured one; the range from low to high includes it.
By their numbers in this assay, from the lowest: compounds 4, 2, 1 and 3 (each within the scatter of the next, the first and the last beyond it).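

In this assay, fluoro in place of hydrogen on the outer ring, para to a large group, gives a 2.1-fold lower number from compound 3 to compound 4 (0.33 log units; beyond the scatter). This makes it the one step of this change shown here that clears the scatter, so a shift that could not be told from noise on the shorter side chain can now be read on the longer one. The two steps still agree closely, so the change behaves alike on both side chains: the same change on two cores in this assay, a 1.8-fold lower number (0.25 log units; within the scatter) from compound 1 to compound 2 and a 2.1-fold lower number (0.33 log units; beyond the scatter) from compound 3 to compound 4, 1.2-fold (0.08 log units) apart, within the scatter of two such steps

The side chain itself gives a 1.0-fold lower number from compound 2 to compound 4 (0.01 log units; within the scatter), so with fluoro on the ring, as with the plain phenyl urea, swapping the dimethylamino chain for the longer diethylamino chain leaves the number in this assay unmoved: the same change on two cores in this assay, a 1.2-fold higher number (0.07 log units; within the scatter) from compound 1 to compound 3 and a 1.0-fold lower number (0.01 log units; within the scatter) from compound 2 to compound 4, 1.2-fold (0.08 log units) apart, within the scatter of two such steps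

On these data alone, whether a chlorine atom, a methoxy group or a trifluoromethyl group in the same place would give a step of similar size remains open, as does the effect of fluoro on another carbon of that ring. Also open, as far as these compounds go, is whether a side chain ending in a morpholine ring or a carboxylic acid would stay as silent as the two amine chains compared here.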